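Chalcone amide series: cytotoxicity notes toward compound 4

A few compounds are considered here, and "the series" means these few. Any claim that something is new, unique, unknown or untested is made for them only; others in the source may bear on it.

Compound 1 `COC(=O)c1cc(-c2cccc(NC(=O)c3ccc(OCc4ccc(Cl)cc4)cc3)c2)on1` in an ADME assay on Vero cells (Chlorocebus sabaeus) for cytotoxicity, read by MTT assay, with a stated time of 72 h (a higher number here means that more compound is tolerated, a lower number that less compound is tolerated), gives > 80 ug/mL, which is a limit of the assay and not a number. Compound 2 `COC(=O)c1cc(-c2cccc(NC(=O)c3ccc(/C=C/C(=O)c4ccccc4OC)cc3)c2)on1` gives > 40 ug/mL, again a limit. Compound 3 `CCCOc1ccc(C(=O)/C=C/c2ccc(C(=O)Nc3cccc(-c4cc(C(=O)OC)no4)c3)cc2)cc1` gives > 40 ug/mL, also a limit. The steps a step that the two limits leave unreadable from compound 1 to compound 2 and a step that the two limits leave unreadable from compound 2 to compound 3 therefore cannot be sized; what is known is the limit of > 40 ug/mL in this assay, at which 2 of the 3 values shown sit, and (the limit of > 80 ug/mL in this assay, at which 1 of the 3 values shown sits). Compound 3 thus stands at a limit only, as do the other two values. Compound 4 `COC(=O)c1cc(-c2cccc(NC(=O)c3ccc(/C=C/C(=O)c4ccccc4Br)cc3)c2)on1` differs by 2-bromophenyl in place of 4-propoxyphenyl on a carbonyl carbon. The step from compound 2 to compound 3 likewise swapped the aryl on the carbonyl carbon without a readable change. The expected step that the limit leaves unreadable from compound 3 to compound 4 is none beyond the scatter. Compound 4 is estimated at 50 ug/mL, range 20 ug/mL to 120 ug/mL.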

Compound 4, half-maximal cytotoxic concentration: > 40 ug/mL
Compound 4 gave a limit, no number (the forecaster's own chance of this, stated with the estimate: 75%); the middle value lies beyond the limit too.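

For the compounds shown here, compound 4 also stands at a limit, not a number, so no step linking it to compound 1, compound 2 or compound 3 can be read. Left open is the actual half-maximal cytotoxic concentration of all four compounds, and whether 2-bromophenyl in place of 4-propoxyphenyl changes it at all.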